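Amide Nitrogen Substituents and Tolerated Concentration in Liver Cells

The compounds below may be only part of what the source reports. "The series", "measured", "known", "first", "only" and "open" are said of these compounds alone.

Compound 1, `COc1ccc(NC(=O)/C=C/c2coc3cc(O)ccc3c2=O)cc1`: 976000 nM
Compound 2, `Cc1ccccc1NC(=O)/C=C/c1coc2cc(O)ccc2c1=O`: 374000 nM
Compound 3, `Cc1ccc(CNC(=O)/C=C/c2coc3cc(O)ccc3c2=O)cc1`: 501000 nM

Three compounds sharing one core and differing only in the group on the amide-type nitrogen were tested in an ADME assay on HepG2 2.2.15 cells (Homo sapiens) for cytotoxicity, read by MTT assay, with stated times of 48 h and 9 days; a lower number here means that less compound is tolerated, a higher number that more compound is tolerated. Compound 3 stands second highest of the three numbers; its nearest neighbour is compound 2, and the gap between them is within the scatter, as is the gap to compound 1 at the top. The only difference that reached beyond the scatter is a 2.6-fold lower number from compound 1 to compound 2 (0.42 log units; beyond the scatter), a modest one; a 1.9-fold lower number from compound 1 to compound 3 (0.29 log units; within the scatter) and a 1.3-fold higher number from compound 2 to compound 3 (0.13 log units; within the scatter) both stay within it.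

Compound 4, `O=C(/C=C/c1coc2cc(O)ccc2c1=O)Nc1ccccc1`, has not yet been measured. It differs from compound 3 by phenyl in place of 4-methylbenzyl on an amide-type nitrogen. Within the data shown here, no measured step removes exactly this group, but all three steps swap one group for another on the same nitrogen and none moved the number by more than a modest amount. Compound 4 is therefore expected to land close to compound 3, with a step of about a 1.2-fold higher number from compound 3 to compound 4 (0.08 log units; within the scatter) that should sit within the scatter. Compound 4 is estimated at 600000 nM, within a range of 300000 nM to 1200000 nM.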

Compound 4, half-maximal cytotoxic concentration: 821000 nM
Compound 4: the middle estimate sits 1.4-fold (0.14 log units) below what was measured; measured number inside the range.
By their numbers in this assay, from the lowest: compounds 2, 3, 4 and 1 (each within the scatter of the next, the first and the last beyond it).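

With the plain phenyl on the amide-type nitrogen in hand, the one modest difference seen so far can be placed more exactly: in this assay, hydrogen in place of the methyl of the 2-methylphenyl group gives a step beyond the scatter (a 2.2-fold higher number from compound 2 to compound 4 (0.34 log units; beyond the scatter)), while hydrogen in place of the methoxy of the 4-methoxyphenyl group gives one within it (a 1.2-fold lower number from compound 1 to compound 4 (0.08 log units; within the scatter)). Among the compounds with the ring directly on this nitrogen, compound 2 therefore stands apart from the other two, whereas the methoxy group brings no readable change from phenyl; compound 3 does not share that separation, since the exchange of 4-methylbenzyl for phenyl stays within the scatter (a 1.6-fold higher number from compound 3 to compound 4 (0.21 log units; within the scatter)) and compound 3 also lies within the scatter of compound 2. Nothing measured here accounts for any of these steps. As far as these compounds go, whether the step belongs to a methyl group in that particular place, or would also follow a chlorine or an ethyl group there, remains open. Also open, from the compounds shown here alone, is how this tolerated concentration would respond to a carboxylic acid or an amine on the ring, or to a longer chain joining the ring to the nitrogen.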